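Replacing the acid of compound 3 with a basic amine

The source may hold more compounds than are shown below. What is called first, only, known or untested is meant among the compounds shown, and "the series" means these compounds.

Of the compounds shown here, three sharing one core have been measured in a functional assay on CHO cells for inhibition of transient receptor potential cation channel subfamily V member 1 (Homo sapiens); a higher number here means a weaker inhibitor, a lower number a stronger inhibitor. Compound 1 `CC(C)(C)c1ccc(/C(=C/C(=O)Nc2ccc3c(c2)OCCO3)c2ccncc2)cc1` gives 44 nM. Compound 2 `CCOC(=O)CC/C(=C\C(=O)Nc1ccc2c(c1)OCCO2)c1ccc(C(C)(C)C)cc1` gives 36 nM, and the step of a 1.2-fold lower number from compound 1 to compound 2 (0.09 log units; within the scatter) is small. Compound 3 `CC(C)(C)c1ccc(/C(=C/C(=O)Nc2ccc3c(c2)OCCO3)CCC(=O)O)cc1` is different: its result in this assay is a limit, > 4000 nM, not a number. Compound 3 therefore sits at the edge of what this assay can report, as shown by the limit of > 4000 nM in this assay, at which 1 of the 3 values shown sits. Among the compounds with values here, the steps of an at least 90-fold higher number from compound 1 to compound 3 (1.95 log units; beyond the scatter) and an at least 110-fold higher number from compound 2 to compound 3 (2.04 log units; beyond the scatter) are both large, and both end at compound 3, the only compound carrying a carboxy group.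

Compound 4 `CN(C)CCC/C(=C\C(=O)Nc1ccc2c(c1)OCCO2)c1ccc(C(C)(C)C)cc1` is not yet measured. It differs from compound 3 by (dimethylamino)methyl in place of carboxy on a saturated chain carbon, two bonds along the chain from a double-bonded chain carbon. The carboxy group that marks compound 3 is thus removed, and the step from compound 2 to compound 3 is the one that bears most directly on this change, since it shows what arrived with that group. Compound 1 and compound 2, which lack the acid, both sit far from the limit. Compound 4 is therefore expected to move back toward those two, with a large downward step an at least 33-fold lower number from compound 3 to compound 4 (1.52 log units; beyond the scatter). The estimate for compound 4 in this assay is 120 nM, within a range from 30 nM to 800 nM.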

Compound 4, half-maximal inhibitory concentration: 3900 nM
Estimate against measurement, compound 4: 33-fold (1.51 log units) below, outside the stated range (above it).
By their numbers in this assay, from the lowest: compounds 2 and 1 (each within the scatter of the next); then compound 4. At a limit, above all of these: compound 3.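

Replacing the carboxy group with (dimethylamino)methyl at this position does not bring back the numbers seen with the ester and with the pyridin-4-yl group: in this assay the change from the ester gives a 110-fold higher number from compound 2 to compound 4 (2.03 log units; beyond the scatter), and the change from the pyridine gives an 89-fold higher number from compound 1 to compound 4 (1.95 log units; beyond the scatter). From the compounds shown here alone, compound 3 is reported only as a limit, > 4000 nM, so the change from the acid to the amine can be read only as a floor, an at least 1.0-fold lower number from compound 3 to compound 4 (0.01 log units; that floor lies within the scatter), and its true size stays unknown: the limit of > 4000 nM in this assay, at which 1 of the 4 values shown sits. Among these four compounds, then, the large loss is not confined to the carboxylic acid, since the amine of compound 4 also stands far from compound 1 and compound 2.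

The compounds shown leave open which feature of the ethoxycarbonyl group of compound 2 goes with its low number, a question that a methyl ester, an amide or an alcohol at the end of the same chain could help to answer. They also leave open whether a shorter or longer chain carrying the dimethylamino group, or a cyclic amine such as morpholine, would change the result in this assay.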